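Two Stereocentres Redrawn: From Compound 2 to Compound 4

A few compounds are considered here, and "the series" means these few. Any claim that something is new, unique, unknown or untested is made for them only; others in the source may bear on it.

In a functional assay on A549 cells (Homo sapiens) for antiproliferative activity (a lower number here means a stronger inhibitor of growth, a higher number a weaker inhibitor of growth), compound 2 `CC/C=C\[C@H](C)[C@H](OC(N)=O)[C@@H](C)[C@H](O)[C@@H](C)C/C(C)=C\[C@H](C)[C@@H](O)[C@@H](C)/C=C\[C@@H](O)C[C@H]1CCC(=O)O1` gives 63 nM. Compound 1 `CC/C=C\[C@H](C)[C@H](OC(N)=O)[C@@H](C)[C@H](O)[C@@H](C)C/C(C)=C\[C@H](C)[C@@H](O)[C@@H](C)/C=C\[C@@H](O)C[C@@H]1OC(=O)[C@H](C)C[C@H]1C` gives 50 nM, within the scatter of compound 2, while compound 3 `CC/C=C\[C@H](C)[C@H](OC(N)=O)[C@@H](C)[C@H](O)[C@@H](C)C/C(C)=C\[C@H](C)[C@@H](O)[C@@H](C)/C=C\[C@@H](O)C[C@H](O)[C@H](C)C[C@H](C)C(=O)OC`, the weakest of the three, gives 4000 nM. Compound 4 `CC/C=C\[C@H](C)[C@H](OC(N)=O)[C@@H](C)[C@H](O)[C@@H](C)C/C(C)=C\[C@H](C)[C@@H](O)[C@@H](C)/C=C\[C@H](O)C[C@@H]1CCC(=O)O1` has not yet been measured. Compared with compound 2, it shows this difference: the two compounds have the same atoms and bonds and differ only in configuration as drawn: 2 of 13 stereo elements differ; a stereocentre at a saturated chain carbon is drawn S in compound 2 and R in compound 4; a stereocentre at a saturated ring carbon is drawn R in compound 2 and S in compound 4.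

Going by the values given here, no measured step tests a change of configuration alone. The closest evidence comes from changes to the group on the same saturated chain carbon. Exchanging the six-membered ring for the five-membered ring gave a 1.3-fold higher number from compound 1 to compound 2 (0.10 log units; within the scatter). Replacing either ring with a group that has no ring gave an 80-fold higher number from compound 1 to compound 3 (1.90 log units; beyond the scatter) and a 63-fold higher number from compound 2 to compound 3 (1.80 log units; beyond the scatter).

These steps show that changes to this group can be tolerated or can be costly, but not how its configuration counts. A moderate loss is therefore expected, smaller than a 63-fold higher number from compound 2 to compound 3 (1.80 log units; beyond the scatter) seen with compound 3, and the estimated step is a 3.2-fold higher number from compound 2 to compound 4 (0.50 log units; beyond the scatter). Compound 4 is estimated at 200 nM, with an expected range of 50 nM to 1500 nM.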

Compound 4, concentration for 50% growth inhibition: 10000 nM
Compound 4: middle estimate off by 50-fold (1.70 log units), on the low side, outside the stated range (above it).
By their numbers in this assay, from the lowest: compounds 1 and 2 (each within the scatter of the next); then compound 3; then compound 4.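

Inverting two stereocentres alone gives a 160-fold higher number from compound 2 to compound 4 (2.20 log units; beyond the scatter), so this part of the molecule is sensitive to its configuration and not only to which group it carries. That loss can be assigned to configuration because nothing else changes: the fact that compounds 2 and 4 differ only in the configuration as drawn. Another step, a 200-fold higher number from compound 1 to compound 4 (2.30 log units; beyond the scatter), mixes the same inversion with the change from the six-membered ring to the five-membered ring, so it gives no separate reading of either change.

The compounds shown leave open whether the stereocentre at the saturated chain carbon, the one at the saturated ring carbon, or only the two together account for the loss. They also leave open how a lactam ring or a carboxylic acid in place of the five-membered ring would fare in either configuration.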